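The source may report more compounds than this note shows. Statements on the series, on what has been measured and on what is new or still open speak of the compounds shown alone.

Compound 1 `Cc1cc(CNC(=O)c2nc3ccc(F)c(OCCc4ccc(C(=O)O)cc4)c3c(=O)[nH]2)ccc1F` and compound 2 `CC(C)c1cccc(CNC(=O)c2nc3ccc(F)c(OCCc4ccc(C(=O)O)cc4)c3c(=O)[nH]2)c1` share one core and differ only in the group on a saturated chain carbon bound to an amide-type nitrogen, 3-isopropylphenyl in place of 4-fluoro-3-methylphenyl. In an ADME assay on HEK293 cells (Homo sapiens) for cytotoxicity, read by resazurin assay, with a stated time of 72 h (on this read-out higher numbers stand for lower toxicity in this test and lower numbers for higher toxicity in this test), compound 1 gives > 20000 nM, which is a limit of the test rather than a measured number. In this assay compound 2 gives > 20000 nM, again a limit. The step that the two limits leave unreadable from compound 1 to compound 2 therefore cannot be read as a size, and the limit of > 20000 nM in this assay, at which 2 of the 2 values shown sit, is all the two values show. Compound 3 `CCc1cccc(C(C)NC(=O)c2nc3ccc(F)c(OCCc4ccc(C(=O)O)cc4)c3c(=O)[nH]2)c1` differs from compound 2 by 1-(3-ethylphenyl)ethyl in place of 3-isopropylbenzyl on an amide-type nitrogen; the two have the same atoms joined differently. Among the compounds with values here, no measured step resolves a number for a change of this kind. The step that the limit leaves unreadable from compound 2 to compound 3 that I expect stays within the scatter. I estimate that compound 3 gives 25000 nM, within 10000 nM to 60000 nM, and most likely is again reported only as a limit.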

Compound 3, half-maximal cytotoxic concentration: > 20000 nM
Compound 3 was reported as a limit; the forecaster's own chance of this, stated with the estimate: 80%; the middle value does not contradict the limit.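

Compound 3 is reported only as a limit, as are compound 1 and compound 2, so no step among these three compounds can be read as a size: the limit of > 20000 nM in this assay, at which 3 of the 3 values shown sit. The compounds shown leave open at what concentration, if any, each becomes toxic in this assay.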